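The compounds below may be only part of what the source reports. "The series", "measured", "known", "first", "only" and "open" are said of these compounds alone.

Measured so far:
compound 2 `O=S(=O)(NCCCNCc1ccc(Cl)c(Cl)c1)c1cc(C(F)(F)F)cc(C(F)(F)F)c1`: 1800 nM
compound 1 `O=S(=O)(NCCNCc1cccc2ccccc12)c1cc(C(F)(F)F)cc(C(F)(F)F)c1`: 21000 nM

In a functional assay on Capan-2 cells (Homo sapiens) for inhibition, read by MTT assay, with a stated time of 72 h (a higher number here means a weaker inhibitor of growth, a lower number a stronger inhibitor of growth), compound 2 gives the lower of the two numbers, and the value of compound 1 lies above it by a margin beyond the usual scatter. Among the measured compounds shown here, no pair of measured compounds differs in a single place, so no measured step is available. Compound 3 `O=S(=O)(NCCCNCc1ccc(Br)cc1)c1cc(C(F)(F)F)cc(C(F)(F)F)c1` has not yet been measured in this assay. It differs from compound 2 in one place: 4-bromophenyl in place of 3,4-dichlorophenyl on a saturated chain carbon bound to an amine nitrogen. Neither measured compound shows this particular change, so the expectation rests only on the standing of compound 2. Relative to compound 2, compound 3 is expected to move toward a higher number in this assay, a step of a 1.9-fold higher number from compound 2 to compound 3 (0.29 log units; within the scatter), modest in size and probably beyond the scatter. For compound 3 the estimate in this assay is 3500 nM, with a range from 1200 nM to 12000 nM.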

Compound 3, concentration for 50% growth inhibition: 2000 nM
Estimate against measurement, compound 3: 1.8-fold (0.24 log units) above; the measured number falls inside the stated range.
By their numbers in this assay, from the lowest: compounds 2 and 3 (each within the scatter of the next); then compound 1.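

In this assay, 4-bromophenyl in place of 3,4-dichlorophenyl on a saturated chain carbon bound to an amine nitrogen gives a 1.1-fold higher number from compound 2 to compound 3 (0.05 log units; within the scatter), so the two compounds cannot be told apart. Among the compounds shown here, this is the first single change measured at this position, and it shows that a ring carrying two chlorine atoms and a ring carrying one bromine atom read alike here, even with one heavy atom fewer in the group that enters. No evidence is available that bears on this result.

The compounds shown leave open how a plain phenyl, a 4-methoxyphenyl or a pyridine ring would read in this place. Compound 1 differs from compound 2 and compound 3 in more than one place, so its separate standing cannot be traced to any single part.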